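Swapping the aryl group on the sulfonamide nitrogen

This account rests on a few compounds, and the source may have more. Where it says the series, first, only, none or still open, it means among the compounds named here.

Compound 2 `O=[N+]([O-])c1ccc(NS(=O)(=O)c2ccc3nc(-c4ccccc4)c(-c4ccccc4)nc3c2)cc1` is one of two measured compounds; the other is compound 1 `O=S(=O)(Nc1ccccn1)c1ccc2nc(-c3ccccc3)c(-c3ccccc3)nc2c1`, which differs only in the group on the sulfonamide nitrogen. In an ADME assay on the whole organism for pharmacokinetics, with Homo sapiens as the target (on this read-out lower numbers stand for lower oral bioavailability and higher numbers for higher oral bioavailability), compound 1 gives 100%, and compound 2 gives 87.6%. Among these two numbers compound 2 stands lowest, and the step of a number 12.4 percentage points lower from compound 1 to compound 2 (beyond the scatter) lies beyond the scatter while remaining modest. Compound 3 `CC(=O)c1cccc(NS(=O)(=O)c2ccc3nc(-c4ccccc4)c(-c4ccccc4)nc3c2)c1` has not been measured. It differs from compound 2 by 3-acetylphenyl in place of 4-nitrophenyl on a sulfonamide nitrogen. Going by the values given here, only one measured step exists, and it also changes the group on that nitrogen, but it swaps a different pair of groups, so it does not speak directly to the change at hand; nothing shows how replacing the nitro group by an acetyl group plays out in this assay. Because a number 12.4 percentage points lower from compound 1 to compound 2 (beyond the scatter) was modest, the step expected for compound 3 is small: a number 0.4 percentage points higher from compound 2 to compound 3 (within the scatter). Compound 3 is therefore estimated at 88% in this assay, with a range from 70% to 100%.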

Compound 3, oral bioavailability: 96.9%
Compound 3: the middle estimate sits 8.9 percentage points below what was measured; the range from low to high includes it.
By their numbers in this assay, from the lowest: compounds 2, 3 and 1 (each within the scatter of the next, the first and the last beyond it).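

In this assay, 3-acetylphenyl in place of 4-nitrophenyl on the sulfonamide nitrogen gives a number 9.3 percentage points higher from compound 2 to compound 3 (within the scatter), while 3-acetylphenyl in place of pyridin-2-yl gives a number 3.1 percentage points lower from compound 1 to compound 3 (within the scatter), so compound 3 cannot be told apart from either of the other two. Compound 1 and compound 2 alone could have suggested that a ring of carbon only on this nitrogen lowers oral bioavailability, but compound 3 also carries such a ring and still lies within the scatter of compound 1, so the pattern does not hold across all three compounds. No measured evidence here explains these numbers.

Compound 2 and compound 3 differ in both the group on the ring and the place it occupies, so the compounds shown cannot separate these two parts of the change. Going by these compounds, it also remains open how this read-out would respond to a carboxylic acid or an amine on the phenyl ring, or to a plain ethyl chain on the sulfonamide nitrogen in place of the aromatic ring.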